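The compounds below may be only part of what the source reports. "The series", "measured", "known", "first", "only" and "open" are said of these compounds alone.

Compound 1 `Cc1c(Cc2c(F)cccc2F)nc(N2CCCC(C)C2)[nH]c1=O`: > 75000 nM (a limit)
Compound 2 `Cc1c(C(C)c2c(F)cccc2F)nc(N(C)C)[nH]c1=O`: > 17000 nM (a limit)
Compound 3 `Cc1c(C(C)c2c(F)cccc2F)nc(N2CCCCC2)[nH]c1=O`: > 75000 nM (a limit)

In an ADME assay on MT4 cells (Homo sapiens) for cytotoxicity, read by MTT assay, with a stated time of 4 days (on this read-out lower numbers stand for higher toxicity in this test and higher numbers for lower toxicity in this test), all three compounds give only limits, so the series has no exact reading yet. In this assay compound 3 stands at the limit > 75000 nM. This is the limit of > 75000 nM in this assay, at which 2 of the 3 values shown sit.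

Compound 4 `Cc1c(C(C)c2c(F)cccc2F)nc(N2CCCC(C)C2)[nH]c1=O` has methyl in place of hydrogen on a saturated ring carbon of compound 3, two ring bonds from the ring nitrogen (methyl in place of hydrogen on a saturated ring carbon). Piperidin-1-yl thus becomes 3-methylpiperidin-1-yl. Going by the values given here, the only measured step is a step that the two limits leave unreadable from compound 2 to compound 3, and it concerns a different change, so it offers no size to carry over.

The closest guide is compound 1, which also carries 3-methylpiperidin-1-yl and also gives a limit, > 75000 nM. On that value, no change beyond the scatter is expected, and the expected step is a number no higher from compound 3 to compound 4 (the limit leaves the size open). For compound 4 the estimate is 75000 nM, with an expected range of 25000 nM to 150000 nM, most likely reported again as a limit.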

Compound 4, half-maximal cytotoxic concentration: > 72000 nM
Compound 4 ended at the assay's limit; the forecaster's own chance of this, stated with the estimate: 85%; the middle value is on the limit's open side.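

In this assay compound 4 gives > 72000 nM, which is a limit. With compound 1, compound 2 and compound 3 also giving only limits, no step among these compounds can be read. The compounds shown leave open at what concentration any of them becomes toxic to the cells.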